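A few compounds are considered here, and "the series" means these few. Any claim that something is new, unique, unknown or untested is made for them only; others in the source may bear on it.

Measured so far in a functional assay (brain) for inhibition, with Rattus norvegicus as the target; on this read-out higher numbers stand for weaker inhibition and lower numbers for stronger inhibition:
- compound 1 `CCNc1cccnc1N1CCN(C(=O)C2(C)CCc3c(C)c(O)c(C)c(C)c3O2)CC1` gives 12000 nM
- compound 2 `Cc1c(C)c2c(c(C)c1O)CCC(C)(C(=O)N1CCN(c3ncccn3)CC1)O2` gives 23000 nM

Going by the values given here, compound 2 stands level with compound 1 in this assay: the only step between them, a 1.9-fold higher number from compound 1 to compound 2 (0.28 log units; within the scatter), lies within the scatter, so neither number can be called higher or lower with confidence. The next compound, compound 3 `Cc1c(C)c2c(c(C)c1O)CCC(C)(C(=O)N1CCN(c3ccc(Cl)cc3)CC1)O2`, is built from compound 2 by one change: 4-chlorophenyl in place of pyrimidin-2-yl on an amine nitrogen in a ring. Among the compounds with values here, only one measured step bears on this change, and only loosely: the step from compound 1 to compound 2 also swaps the group on the same ring nitrogen, and it stayed within the scatter. Within the data shown here, no measured compound carries a 4-chlorophenyl there, so the size of this step is unknown. On that basis no step beyond the scatter is expected, with a wide range. Compound 3 is therefore estimated at 20000 nM, between 6000 nM and 70000 nM. The expected step is a 1.2-fold lower number from compound 2 to compound 3 (0.06 log units; within the scatter).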

Compound 3, half-maximal inhibitory concentration: 800 nM
The estimate for compound 3 lay 25-fold (1.40 log units) above the measured number, and the stated range ends above it.
By their numbers in this assay, from the lowest: compound 3; then compounds 1 and 2 (each within the scatter of the next).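

In this assay, the group on this ring nitrogen turns out to matter greatly: 4-chlorophenyl in place of pyrimidin-2-yl gives a 29-fold lower number from compound 2 to compound 3 (1.46 log units; beyond the scatter), and 4-chlorophenyl in place of 3-(ethylamino)pyridin-2-yl gives a 15-fold lower number from compound 1 to compound 3 (1.18 log units; beyond the scatter). The swap between the two nitrogen-containing rings had stayed within the scatter, so the position looked insensitive, but among these three compounds the only one with an aromatic ring of carbon only and a chlorine stands clearly apart, with no compound shown going against this. Nothing measured here explains why this change has so large an effect.

The change removes the ring nitrogens and adds chlorine in one move, so the compounds shown cannot say which of the two matters. A plain phenyl group on the same nitrogen, or a pyridine ring carrying chlorine, would begin to separate them.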